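The source may hold more compounds than are shown below. What is called first, only, known or untested is meant among the compounds shown, and "the series" means these compounds.

Measured in an ADME assay on MRC5 cells (Homo sapiens) for inhibition, with a stated time of 72 h; a lower number here means that less compound is needed, a higher number that more compound is needed for the effect:
Compound 1 `CO[C@H]1CC[C@H](NC(=O)c2n[nH]cc2NC(=O)c2c(C)nc3ccccn23)CC1` gives 34000 nM.
Compound 2 `COc1cccc(OC)c1C(=O)Nc1c[nH]nc1C(=O)NN1CCOCC1` gives only a limit of the assay, > 50000 nM.
Compound 3 `CO[C@H]1CC[C@H](NC(=O)c2n[nH]cc2NC(=O)c2ccc(OC(F)F)cc2)CC1` gives 2500 nM.

Compound 2 stands at the limit of > 50000 nM in this assay, at which 1 of the 3 values shown sits, with no number of its own in this assay. Compound 4 `COc1cccc(OC)c1C(=O)Nc1c[nH]nc1C(=O)NCCCN(C)C` differs from compound 2 by 3-(dimethylamino)propyl in place of morpholin-4-yl on an amide-type nitrogen. Going by the values given here, no pair of measured compounds shares this change, so its size cannot be read from the data; the step in this assay is expected to be small, not clearly beyond the scatter, with at most a modest move toward a measurable number. For compound 4 the expected value is 40000 nM, within a range of 15000 nM to 90000 nM. The estimated step is an at least 1.2-fold lower number from compound 2 to compound 4 (0.09 log units; that floor lies within the scatter).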

Compound 4, half-maximal effective concentration: > 50000 nM
Compound 4: no number, only a limit; the forecaster's own chance of this, stated with the estimate: 50%; middle value at least 1.2-fold (0.09 log units) from the limit.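

No step can be read from compound 2 to compound 4 in this assay, as each gives only a limit: the limit of > 50000 nM in this assay, at which 2 of the 4 values shown sit.

Going by these compounds, whether 3-(dimethylamino)propyl in place of morpholin-4-yl on an amide-type nitrogen changes the number at all stays open.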